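Swapping the furan arm for a methylthiazole on the shared core

This account rests on a few compounds, and the source may have more. Where it says the series, first, only, none or still open, it means among the compounds named here.

Measured so far:
compound 1, `Nc1nc(-c2ccco2)nc2sc(CN3CCC(=O)CC3)cc12`, 2720 nM
compound 2, `CC(C)c1ccc(-c2nc(N)c3cc(CN4[C@H](C)CCC[C@@H]4C)sc3n2)o1`, 140 nM
compound 3, `Nc1nc(-c2ccc(Cl)o2)nc2sc(CN3CCCC3)cc12`, 710 nM

All three numbers come from an assay on CHO-K1 cells for antagonist activity at adenosine receptor A1 (Homo sapiens), read by a beta-galactosidase reporter, with stated times of 15 min and 6 h; on this read-out lower numbers stand for stronger inhibition and higher numbers for weaker inhibition. Compound 2 stands lowest of the three: in this assay compound 2 gives 140 nM, the nearest number being that of compound 3 at 710 nM and the furthest that of compound 1 at 2720 nM, both gaps beyond the usual scatter. The three compounds differ in more than one place at once, so no single change can be read off from any pair of them; only their values themselves can be compared.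

Compound 4, `Cc1csc(-c2nc(N)c3cc(CN4[C@H](C)CCC[C@@H]4C)sc3n2)n1`, has not yet been measured. It differs from compound 2 in one place: 4-methyl-1,3-thiazol-2-yl in place of 5-isopropylfuran-2-yl on an aromatic carbon. Going by the values given here, nothing among the measured compounds tells what this exchange does, as each of them keeps a furan-type arm at that carbon. With no guide, a modest weakening is expected rather than a gain, and the step of a 2.9-fold higher number from compound 2 to compound 4 (0.46 log units; beyond the scatter) is the estimated size of that move. Compound 4 is expected to give about 400 nM in this assay, within a range from 120 nM to 1400 nM.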

Compound 4, inhibition constant: 300 nM
Beside the measured number, compound 4's estimate is 1.3-fold (0.12 log units) above it; the measured number falls inside the stated range.
By their numbers in this assay, from the lowest: compound 2; then compound 4; then compound 3; then compound 1.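

Putting 4-methyl-1,3-thiazol-2-yl in place of 5-isopropylfuran-2-yl in this assay gives a 2.1-fold higher number from compound 2 to compound 4 (0.33 log units; beyond the scatter), a modest weakening that still lies beyond the scatter. Going by these compounds alone, this is the first sign that this aromatic carbon, between two ring nitrogen atoms, can carry something other than a furan-type arm and keep measurable inhibition, even though the entering ring has two hetero atoms and the group has fewer heavy atoms overall. The ring and its alkyl group change together in this one step, so the effects of the two cannot be separated, and no measurement here explains the change.

From the compounds shown here alone, it remains open whether the weakening follows the ring or the alkyl group, a question that a 4-isopropyl-1,3-thiazol-2-yl group or an unsubstituted 1,3-thiazol-2-yl group at this carbon could help to answer. Also unknown are how a phenyl ring would fare here and whether the same exchange would give a similar step on a compound carrying a different side arm, such as that of compound 3.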